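Swapping fluoro for an amide chain on compound 1

The source may hold more compounds than are shown below. What is called first, only, known or untested is meant among the compounds shown, and "the series" means these compounds.

compound 1 `CCC1C(=O)N(C)c2cnc(-n3ccc4cc(F)ccc43)nc2N1c1ccn(C)n1`: 6070 nM
compound 2 `CCCNC(=O)c1ccc2c(ccn2-c2ncc3c(n2)N(C2CCCC2)[C@H](CC)C(=O)N3C)c1`: 395 nM

Within the data shown here, in a functional assay on K562 cells (Homo sapiens) for antiproliferative activity, read by CCK-8 assay, with a stated time of 72 h (a lower number here means a stronger inhibitor of growth, a higher number a weaker inhibitor of growth), compound 1 stands at the higher of the two numbers, 6070 nM, and its only measured neighbour, compound 2, lies lower at 395 nM, a gap beyond the scatter. The next compound to be tested is compound 3 `CCC1C(=O)N(C)c2cnc(-n3ccc4cc(C(=O)NCC(C)C)ccc43)nc2N1c1ccn(C)n1`. It keeps the core of compound 1 and changes one group: isobutylcarbamoyl in place of fluoro on an aromatic carbon. In words, isobutylcarbamoyl takes the place of fluoro on an aromatic carbon of a six-membered aromatic ring of carbon only, part of a fused or bridged system of two rings.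

Among the measured compounds shown here, no measured pair isolates this change, so any expectation rests on thin evidence. Of the two measured compounds, only compound 2 carries an amide chain, and compound 2 gives 395 nM. However, compound 2 also differs from compound 1 elsewhere, so it offers only partial support. A move to a lower number in this assay, beyond the scatter but probably not the full gap, is therefore expected. The expected step is a 6.7-fold lower number from compound 1 to compound 3 (0.83 log units; beyond the scatter). For compound 3 the estimated value is 900 nM, with an expected range from 200 nM to 4000 nM.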

Compound 3, concentration for 50% growth inhibition: 5600 nM
Beside the measured number, compound 3's estimate is 6.2-fold (0.79 log units) below it, and the stated range ends below it.
By their numbers in this assay, from the lowest: compound 2; then compounds 3 and 1 (each within the scatter of the next).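

In this assay, among these compounds, isobutylcarbamoyl in place of fluoro on an aromatic carbon gives a 1.1-fold lower number from compound 1 to compound 3 (0.04 log units; within the scatter), so at this position the single fluorine and a group of 7 heavy atoms, which brings a hydrogen-bond donor and a hydrogen-bond acceptor, cannot be told apart by this read-out. The earlier pair could not show this, since compound 2 differs from compound 1 in more than one place; this step shows that, on the core of compound 1, an amide chain at this carbon is not enough by itself to reach the lower number of compound 2, 395 nM. The data shown include nothing that explains why this exchange leaves the number within the scatter.

How much of the value of compound 2 comes from its amide chain and how much from its other differences remains unresolved, as no pair among the compounds shown separates them. Also open, as far as these compounds go, is whether an amine, a carboxylic acid or a longer chain on this aromatic carbon would move the number beyond the scatter.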